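Adding a Fluorine to the Benzyl Arm

The source may hold more compounds than are shown below. What is called first, only, known or untested is meant among the compounds shown, and "the series" means these compounds.

Compound 1 `CCOC(=O)C1(Cc2ccccc2)CN(c2ccccc2)Cc2nnn(Cc3ccc(OC)cc3)c21` carries a 4-methoxyphenyl on a saturated chain carbon bound to an aromatic nitrogen. In an ADME assay on HEL cells (Homo sapiens) for cytotoxicity, read by microscopy, with a stated time of 3 days (on this read-out lower numbers stand for higher toxicity in this test and higher numbers for lower toxicity in this test), compound 1 reaches only the limit of the test, > 100000 nM. Compound 2 `CCOC(=O)C1(Cc2ccccc2)CN(c2ccccc2)Cc2nnn(Cc3ccc(Cl)c(Cl)c3)c21` keeps the shared core with 3,4-dichlorophenyl in place of 4-methoxyphenyl. In this assay compound 2 likewise stops at the limit, > 100000 nM. The change from compound 1 to compound 2 is therefore a step that the two limits leave unreadable from compound 1 to compound 2, and the limit of > 100000 nM in this assay, at which 2 of the 2 values shown sit, offers no further footing. Compound 3 `CCOC(=O)C1(Cc2ccc(F)cc2)CN(c2ccccc2)Cc2nnn(Cc3ccc(Cl)c(Cl)c3)c21` differs from compound 2 by fluoro in place of hydrogen on an aromatic carbon. Going by the values given here, no measured step resembles this change, so the expectation leans on compound 2 sitting at the limit > 100000 nM. Compound 3 is expected at 100000 nM, within 50000 nM to 200000 nM. The step from compound 2 to compound 3 is estimated as a number no higher from compound 2 to compound 3 (the limit leaves the size open), nothing beyond the scatter.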

Compound 3, minimum cytotoxic concentration: > 100000 nM
Compound 3 ended at the assay's limit; the forecaster's own chance of this, stated with the estimate: 80%; the middle value sits exactly at the limit.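

Going by these compounds alone, compound 2 and compound 3 both stop at a limit of the test, so no step between them can be read: the limit of > 100000 nM in this assay, at which 3 of the 3 values shown sit. The compounds shown leave open what fluoro in place of hydrogen changes in this assay.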